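The compounds below may be only part of what the source reports. "The series", "measured", "known", "first", "only" and "open" are said of these compounds alone.

Compounds measured so far:
compound 1, `CN(C)c1ncnc2c1ncn2Cc1ccc(Cl)cc1`: 0%
compound 2, `CN(C)c1ncnc2c1ncn2Cc1ccc([N+](=O)[O-])cc1`: 0%

Compound 1 and compound 2 share one core; they differ only in the group on the aromatic carbon of the benzyl ring. In a functional assay on the whole organism for inhibition, with Rattus norvegicus as the target, at a dose of 25 mg/kg by the intraperitoneal route (on this read-out lower numbers stand for less inhibition and higher numbers for more inhibition at the one dose given (going by the name of the read-out)), compound 1 gives 0% and compound 2 gives 0%; the step of no change at the digits printed from compound 1 to compound 2 (within the scatter) lies within the scatter. Compound 2 thus stands level with compound 1 at the digits shown, both at the bottom of the read-out.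

Compound 3, `CN(C)c1ncnc2c1ncn2Cc1ccc(C#N)cc1`, is not yet measured. Its change from compound 2 is cyano in place of nitro on an aromatic carbon. Among the compounds with values here, the one measured step bears on it only loosely: exchange of one group at the same position, chloro for nitro, left the read-out unchanged. Within the data shown here, no measured step shows a value above the floor, so there is no basis for expecting a rise. The step of no change at the digits printed from compound 2 to compound 3 (within the scatter) is therefore expected to stay within the scatter. For compound 3 the estimate is 0%, with a range from 0% to 15%.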

Compound 3, a percentage reported as inhibition, in the whole organism at one dose (the size of the read-out at that dose, not a potency): 0%
Estimate against measurement, compound 3: no gap at the digits printed; the range from low to high includes it.
By their numbers in this assay, from the lowest: compounds 1, 2 and 3 (each within the scatter of the next).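

In this assay the exchange of nitro for cyano gives no change at the digits printed from compound 2 to compound 3 (within the scatter) and the exchange of chloro for cyano gives no change at the digits printed from compound 1 to compound 3 (within the scatter) on the same aromatic carbon. A third group at this place, with a triple bond where nitro has a double bond, thus leaves the read-out at the floor, and the three compounds cannot be ranked against one another. No measurement at hand offers an explanation for this lack of response.

Still open, from the compounds shown here alone, is whether a group of another kind at this aromatic carbon, such as an amine, a carboxylic acid or a longer chain, would lift the read-out off the floor. The compounds shown also say nothing about changes elsewhere on the shared core, such as replacing the dimethylamino group.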